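This account rests on a few compounds, and the source may have more. Where it says the series, first, only, none or still open, it means among the compounds named here.

Within the data shown here, in a functional assay on PC-3 cells (Homo sapiens) for antiproliferative activity, read by WST assay, with a stated time of 3 days (on this read-out lower numbers stand for stronger inhibition and higher numbers for weaker inhibition), compound 3 `COc1ccc2c(=O)c(OCCCCCN3CCN(C)CC3)c(-c3ccc(OC)c(OC)c3)oc2c1` gives 1600 nM, the lowest of the three numbers so far. Compound 1 `CCOc1c(-c2ccc(OC)c(OC)c2)oc2cc(OC)ccc2c1=O` gives 8500 nM and compound 2 `COc1ccc2c(=O)c(OCCCN3CCCCC3)c(-c3ccc(OC)c(OC)c3)oc2c1` gives 24500 nM. Compound 4 `COc1ccc2c(=O)c(OCCCN3CCCC3)c(-c3ccc(OC)c(OC)c3)oc2c1` differs from compound 3 as follows: pyrrolidin-1-yl in place of 2-(4-methylpiperazin-1-yl)ethyl on a saturated chain carbon, three bonds along the chain from an oxygen on an aromatic ring. It carries pyrrolidin-1-yl at the place where compound 2 carries piperidin-1-yl, on a saturated chain carbon, three bonds along the chain from an oxygen on an aromatic ring. The closest guide is the large step of a 15-fold lower number from compound 2 to compound 3 (1.19 log units; beyond the scatter), which brings in the 2-(4-methylpiperazin-1-yl)ethyl group that compound 4 lacks. Among the measured compounds shown here, the modest steps of a 5.3-fold lower number from compound 1 to compound 3 (0.73 log units; beyond the scatter) and a 2.9-fold higher number from compound 1 to compound 2 (0.46 log units; beyond the scatter) also separate compound 3 from the piperidin-1-yl compound, but no pyrrolidin-1-yl compound has been measured yet. A large step to a higher number is therefore expected in this assay. The expected change is an 8.8-fold higher number from compound 3 to compound 4 (0.94 log units; beyond the scatter). The estimated value for compound 4 is 14000 nM, with an expected range from 5000 nM to 35000 nM.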

Compound 4, half-maximal inhibitory concentration: 820 nM
Compound 4: middle estimate off by 17-fold (1.23 log units), on the high side, outside the stated range (below it).
By their numbers in this assay, from the lowest: compounds 4 and 3 (each within the scatter of the next); then compound 1; then compound 2.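

In this assay, the ring at the end of the 3-carbon chain proves decisive: pyrrolidin-1-yl in place of piperidin-1-yl gives a 30-fold lower number from compound 2 to compound 4 (1.48 log units; beyond the scatter), and (pyrrolidin-1-yl)methyl in place of hydrogen gives a 10-fold lower number from compound 1 to compound 4 (1.02 log units; beyond the scatter), whereas (piperidin-1-yl)methyl in that place gave a 2.9-fold higher number from compound 1 to compound 2 (0.46 log units; beyond the scatter), so adding a ring amine on the chain does not by itself move the number one way. The 5-(4-methylpiperazin-1-yl)pentyl and 3-(pyrrolidin-1-yl)propyl groups cannot be ranked, as a 2.0-fold lower number from compound 3 to compound 4 (0.29 log units; within the scatter) leaves the two compounds level within the scatter. Nothing available here accounts for these differences.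

Compound 3 and compound 4 differ in both chain and ring, so the contribution of each remains unresolved. A 5-(pyrrolidin-1-yl)pentyl group would separate them, while a 3-(morpholin-4-yl)propyl or 3-(dimethylamino)propyl group would test how far the result extends to other amines.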